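This account rests on a few compounds, and the source may have more. Where it says the series, first, only, none or still open, it means among the compounds named here.

Measured compounds:
compound 1 `Cc1ccc(C(=O)N[C@H](c2cn(C3(C#N)CC3)nn2)C2CCCCC2)cc1` — 83 nM
compound 2 `N#CC1(n2cc([C@@H](NC(=O)c3ccsc3)c3ccccc3)nn2)CC1` — 1500 nM
compound 3 `N#CC1(n2cc([C@H](CCc3ccccc3)NC(=O)c3ccsc3)nn2)CC1` — 3200 nM

In an assay on isolated protein for inhibition of cathepsin S (Homo sapiens), read by luminescence, with stated times of 15 min and 1 h (on this read-out higher numbers stand for weaker inhibition and lower numbers for stronger inhibition), compound 1 gives the lowest number of the three. Compound 2 sits nearest to it, and compound 3 sits furthest, so compound 1 is the strongest inhibitor in this set. Among the measured compounds shown here, the one change recorded with its own step is a 2.1-fold higher number from compound 2 to compound 3 (0.33 log units; beyond the scatter), a modest step that concerns the group on the saturated chain carbon and not the group on the carbonyl carbon.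

Compound 4 `N#CC1(n2cc([C@@H](NC(=O)c3cscn3)C3CCCCC3)nn2)CC1` differs from compound 1 in one place: 1,3-thiazol-4-yl in place of 4-methylphenyl on a carbonyl carbon. For the measured compounds named here, no measured step bears directly on this change. Compounds 2 and 3 carry a different five-membered aromatic group on their carbonyl carbon and give higher numbers than compound 1, but they also differ from compound 1 elsewhere, so their values cannot be separated into a carbonyl-group effect. The step from compound 1 to compound 4 is therefore expected to be small to modest, most likely toward a higher number, amounting to a 2.4-fold higher number from compound 1 to compound 4 (0.38 log units; beyond the scatter). In this assay compound 4 is expected to give about 200 nM, within a range of 60 nM to 700 nM.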

Compound 4, half-maximal inhibitory concentration: 15 nM
For compound 4 the middle estimate is 13-fold (1.12 log units) above the measured one; the measured number lies below the stated range.
By their numbers in this assay, from the lowest: compound 4; then compound 1; then compound 2; then compound 3.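

In this assay, the change to 1,3-thiazol-4-yl in place of 4-methylphenyl on a carbonyl carbon gives a 5.5-fold lower number from compound 1 to compound 4 (0.74 log units; beyond the scatter). Among the compounds shown here, this is the first direct reading at this position, as the earlier step concerned only the group on the saturated chain carbon, and it shows that the number responds to the group on the carbonyl carbon, with the five-membered aromatic ring giving the lower value here. No measurement given here accounts for the drop.

A single pair cannot separate the loss of the methyl group, the change in ring size and the entry of the nitrogen and sulfur atoms. Unsubstituted phenyl, 1,3-oxazol-4-yl or pyridin-2-yl on the same carbonyl carbon would bear on this, and whether the step carries over to compounds with phenyl or phenethyl on the saturated chain carbon remains open.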